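Benzoxazolyl replacement on the piperazine nitrogen of compound 3

The compounds below may be only part of what the source reports. "The series", "measured", "known", "first", "only" and "open" are said of these compounds alone.

Compound 3 `O=C(CCCCCN1CCN(c2cccc(C(F)(F)F)c2)CC1)c1ccccc1O` holds the highest number of the three measured in an assay on isolated protein for binding affinity to 5-hydroxytryptamine receptor 7 (Rattus norvegicus) (on this read-out lower numbers stand for stronger inhibition and higher numbers for weaker inhibition), where compound 3 gives 384 nM. Compound 1 `COc1ccccc1N1CCN(CCCCCC(=O)c2ccccc2O)CC1` gives 5.8 nM and compound 2 `O=C(CCCCCN1CCN(c2ccccn2)CC1)c1ccccc1O` gives 105 nM in this assay. The steps among them are all beyond the scatter: an 18-fold higher number from compound 1 to compound 2 (1.26 log units; beyond the scatter), a 66-fold higher number from compound 1 to compound 3 (1.82 log units; beyond the scatter) and a 3.7-fold higher number from compound 2 to compound 3 (0.56 log units; beyond the scatter).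

Compound 4 `O=C(CCCCCN1CCN(c2nc3ccccc3o2)CC1)c1ccccc1O` differs from compound 3 by a single change: 1,3-benzoxazol-2-yl in place of 3-(trifluoromethyl)phenyl on an amine nitrogen in a ring. The closest measured step is the change of aryl group on the same ring nitrogen from compound 2 to compound 3, which was modest and ran toward weaker binding; the step from compound 1 to compound 3 shows the same nitrogen substituent can move the number a great deal. A heteroaryl group entering here is expected to behave more like compound 2 than like compound 3, so a move to a lower number is expected, a 3.8-fold lower number from compound 3 to compound 4 (0.58 log units; beyond the scatter). Compound 4 is therefore estimated at 100 nM in this assay, within 25 nM to 400 nM.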

Compound 4, inhibition constant: 148 nM
Estimate against measurement, compound 4: 1.5-fold (0.17 log units) below; the measured number falls inside the stated range.
By their numbers in this assay, from the lowest: compound 1; then compounds 2 and 4 (each within the scatter of the next); then compound 3.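

In this assay, a 2.6-fold lower number from compound 3 to compound 4 (0.41 log units; beyond the scatter) shows that a second heteroaryl group on the ring nitrogen also lies on the stronger side of 3-(trifluoromethyl)phenyl. The a 1.4-fold higher number from compound 2 to compound 4 (0.15 log units; within the scatter) leaves 1,3-benzoxazol-2-yl and pyridin-2-yl unresolved, so the added five-membered ring brings no readable change from pyridin-2-yl at this position. Heteroaryl over carbon-only aryl is no general rule: a 26-fold higher number from compound 1 to compound 4 (1.41 log units; beyond the scatter) goes against it, with compound 1 carrying a carbon-only aryl group and giving the lowest number of the four.

Nothing available accounts for these differences. Still open, as far as these compounds go, is whether a benzothiazol-2-yl group, with sulfur in place of the ring oxygen, or a 2-ethoxyphenyl group would keep the number near compound 4 or near compound 1.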